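Methyl to benzyl on compound 3

A few compounds are considered here, and "the series" means these few. Any claim that something is new, unique, unknown or untested is made for them only; others in the source may bear on it.

Values from a functional assay on HCT-116 cells (Homo sapiens) for antiproliferative activity, read by MTT assay, with a stated time of 72 h (a higher number here means a weaker inhibitor, a lower number a stronger inhibitor), appear below
Compound 1 `CCOC(=O)c1csc2nc(CN3CCN(Cc4ccccc4)CC3)c(-c3ccc(C)cc3)n12` gives 47800 nM
Compound 2 `CCOC(=O)c1csc2nc(CN3CCN(Cc4ccccc4)CC3)c(-c3ccc(OC)cc3)n12` gives 19600 nM
Compound 3 `CCOC(=O)c1csc2nc(CN3CCN(C)CC3)c(-c3ccc(Br)cc3)n12` gives 93600 nM

Compound 3 at 93600 nM lies within the usual scatter of compound 1 and clearly higher than compound 2, so it is a weaker inhibitor than compound 2 in this assay and cannot be told apart from compound 1.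

Compound 4 `CCOC(=O)c1csc2nc(CN3CCN(Cc4ccccc4)CC3)c(-c3ccc(Br)cc3)n12` differs from compound 3 in one place, methyl to benzyl, and phenyl in place of hydrogen on a saturated chain carbon bound to an amine nitrogen in a ring gives the details. For the measured compounds named here, no measured step covers this change directly. Going by the values given here, the one measured step is a 2.4-fold lower number from compound 1 to compound 2 (0.39 log units; beyond the scatter) and it concerns another change, methoxy in place of methyl on an aromatic carbon, so it offers only a rough idea of how far a single swap moves these numbers.

The remaining hint is also weak. Compound 2 carries benzyl and lies clearly lower than compound 3, while compound 1 also carries benzyl but lies within the scatter of compound 3. Both also differ from compound 3 on the aromatic ring.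

An estimated 2.7-fold lower number from compound 3 to compound 4 (0.43 log units; beyond the scatter) is therefore expected, a modest fall with a range wide enough to include no real change. Compound 4 is expected at 35000 nM with an estimated range from 12000 nM to 90000 nM in this assay when it is measured.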

Compound 4, half-maximal inhibitory concentration: 37200 nM
The estimate for compound 4 lay 1.1-fold (0.03 log units) below the measured number, within the range that was stated.
By their numbers in this assay, from the lowest: compounds 2, 4, 1 and 3 (each within the scatter of the next, the first and the last beyond it).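

In this assay, for the compounds shown here, methyl to benzyl with bromo kept on the aromatic ring gives a 2.5-fold lower number from compound 3 to compound 4 (0.40 log units; beyond the scatter), the first direct reading of this change, and it is a modest step beyond the scatter. With benzyl held in place, bromo in place of methoxy gives a 1.9-fold higher number from compound 2 to compound 4 (0.28 log units; within the scatter) and bromo in place of methyl gives a 1.3-fold lower number from compound 1 to compound 4 (0.11 log units; within the scatter), both within the scatter, so compound 4 cannot be told apart from compound 1 or compound 2. Nothing available explains why benzyl goes with the lower number.

On these data alone, whether benzyl brings a similar step with methyl or methoxy on the aromatic ring stays open, as only the bromo pair shows this change directly. It is also unclear whether the phenyl ring itself matters or simply the larger group on the amine nitrogen, a question that a longer chain such as phenylethyl, a saturated cyclohexylmethyl group or a carboxylic acid at the end of the chain could help to settle.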